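Carboxy in Place of Nitro: Estimating Compound 3

The source may report more compounds than this note shows. Statements on the series, on what has been measured and on what is new or still open speak of the compounds shown alone.

Among the compounds with values here, compound 2 `Cc1csc(NC(=O)Cn2cc(-c3ccc([N+](=O)[O-])cc3)nn2)n1` gives the lowest of the two numbers so far in a functional assay on BMDM cells (Mus musculus, strain C57BL/6) for inhibition, with a stated time of 2 days (a lower number here means a stronger inhibitor, a higher number a weaker inhibitor), at 190 nM. Compound 1 `COc1ccc(-c2cn(CC(=O)Nc3nc(C)cs3)nn2)cc1` gives 3890 nM in this assay, and the step of a 20-fold lower number from compound 1 to compound 2 (1.31 log units; beyond the scatter) was large. Compound 3 `Cc1csc(NC(=O)Cn2cc(-c3ccc(C(=O)O)cc3)nn2)n1` differs from compound 2 by carboxy in place of nitro on an aromatic carbon. Within the data shown here, no measured step swaps nitro for carboxy; the only step at this place, a 20-fold lower number from compound 1 to compound 2 (1.31 log units; beyond the scatter), shows that the number is sensitive to the group there, and a substantial move, most likely toward a higher number, is expected in this assay. Compound 3 is expected to show a 6.3-fold higher number from compound 2 to compound 3 (0.80 log units; beyond the scatter), with an estimate of 1200 nM and a range from 250 nM to 6000 nM.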

Compound 3, half-maximal inhibitory concentration: > 30000 nM
Compound 3: only a limit was reported; the forecaster's own chance of this, stated with the estimate: 10%; at least 25-fold (1.39 log units) between middle value and limit.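

In this assay, carboxy in place of nitro gives an at least 150-fold higher number from compound 2 to compound 3 (2.19 log units; beyond the scatter), and carboxy in place of methoxy gives an at least 7.7-fold higher number from compound 1 to compound 3 (0.88 log units; beyond the scatter). The earlier step showed only that this aromatic carbon tolerates a change of group with a large gain; these steps show that a change here can also carry the number past that of methoxy, so that nitro and carboxy lie far apart. The reading for compound 3 is a limit, not a number: the limit of > 30000 nM in this assay, at which 1 of the 3 values shown sits.

As far as these compounds go, how far compound 3 lies beyond that limit stays open. Also open, from the compounds shown here alone, is where an amine, a nitrile or a methyl ester would fall at this place.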